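The source may report more compounds than this note shows. Statements on the series, on what has been measured and on what is new or still open speak of the compounds shown alone.

Measured compounds:
compound 1, `CC1=CC[C@@H]([C@@](C)(O)CCCC(C)(C)NC=S)CC1`: in a functional assay on MCF7 cells (Homo sapiens) for cytotoxicity, read by sulforhodamine B assay (a lower number here means that less compound is tolerated, a higher number that more compound is tolerated), compound 1 gives > 100000 nM, a limit of the assay.
compound 2, `CC1=CC[C@@H]([C@@](C)(O)CCCC(C)(C)NC(=S)N/N=C\c2ccccc2)CC1`: in this assay compound 2 gives 60400 nM.
compound 3, `CC1=CC[C@@H]([C@@](C)(O)CCCC(C)(C)NC(=S)N/N=C\c2ccccc2[N+](=O)[O-])CC1`: in this assay compound 3 gives > 100000 nM, again a limit of the assay.

Compound 2 is thus the only one of the three with a number in this assay; the other two sit at the limit of > 100000 nM in this assay, at which 2 of the 3 values shown sit. The account concerns compound 4, `CC1=CC[C@@H]([C@@](C)(O)CCCC(C)(C)NC(=S)N/N=C(/C)c2ccccc2)CC1`, which differs from compound 2 in one place: a group of 9 heavy atoms (8 carbon, 1 nitrogen; one six-membered aromatic ring of carbon only) in place of a group of 8 heavy atoms (7 carbon, 1 nitrogen; one six-membered aromatic ring of carbon only), on an amide-type nitrogen. Among the measured compounds shown here, two measured steps touch this region of the molecule. From compound 1 to compound 2 the change was an at least 1.6-fold lower number from compound 1 to compound 2 (0.21 log units; that floor lies within the scatter), and from compound 2 to compound 3 it was an at least 1.6-fold higher number from compound 2 to compound 3 (0.21 log units; that floor lies within the scatter); both rest on a limit and neither is secure beyond the scatter. Nothing in these numbers points to a clear direction for the exchange in compound 4, and no step beyond the scatter is expected. Compound 4 is therefore estimated to give about 60000 nM in this assay, with a range from 25000 nM to 150000 nM. The expected step is accordingly a 1.0-fold lower number from compound 2 to compound 4 (0.00 log units; within the scatter), essentially no change.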

Compound 4, concentration lethal to 50% of the cells: > 100000 nM
Compound 4: no number, only a limit; the forecaster's own chance of this, stated with the estimate: 40%; middle value at least 1.6-fold (0.22 log units) from the limit.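

In this assay compound 4 gives > 100000 nM, which is a limit of the assay and not a number. The exchange on the amide-type nitrogen, where the group of 9 heavy atoms enters in place of the group of 8, gives an at least 1.6-fold higher number from compound 2 to compound 4 (0.21 log units; that floor lies within the scatter), so this change does not bring the number below that of compound 2, but the step is not secure either, and it cannot be said that the exchange moves the number at all. What the earlier compounds did not show is that this second change in the same region, like the nitro exchange, also leaves compound 2 as the only compound with a number, with all the others at one limit: the limit of > 100000 nM in this assay, at which 3 of the 4 values shown sit.

How far compound 4 lies past that limit stays open, and with it the true size of the step, so the compounds shown cannot rank this exchange against the nitro exchange. They also leave open how the number would read with an amine, a carboxylic acid or a longer carbon chain in the group on the amide-type nitrogen.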